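Methyl in place of methoxy on the pendant phenyl

This account rests on a few compounds, and the source may have more. Where it says the series, first, only, none or still open, it means among the compounds named here.

Compound 1 `COC1Cc2c(-c3ccccc3)csc2C2(CCN(Cc3ccccc3)CC2)O1` gives 5.4 nM in an assay on membranes from brain for displacement of a labelled ligand from Sigma non-opioid intracellular receptor 1 (Cavia porcellus), read by scintillation counting, with a stated time of 120 min; a higher number here means a weaker inhibitor, a lower number a stronger inhibitor. Compound 2 `COc1ccc(-c2csc3c2CC(OC)OC32CCN(Cc3ccccc3)CC2)cc1` gives 7.1 nM in this assay, and the step of a 1.3-fold higher number from compound 1 to compound 2 (0.12 log units; within the scatter) shows that the two numbers sit within the scatter of each other. Compound 3 `COC1Cc2c(-c3ccc(C)cc3)csc2C2(CCN(Cc3ccccc3)CC2)O1` differs from compound 2 by methyl in place of methoxy on an aromatic carbon. Within the data shown here, the only measured step touching this position, a 1.3-fold higher number from compound 1 to compound 2 (0.12 log units; within the scatter), stayed within the scatter, so no change beyond the scatter is expected in this assay, and the step of a 1.2-fold lower number from compound 2 to compound 3 (0.07 log units; within the scatter) is estimated to be small. For compound 3 the expected value is 6 nM, with a range from 3 nM to 12 nM.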

Compound 3, inhibition constant: 2.7 nM
Beside the measured number, compound 3's estimate is 2.2-fold (0.35 log units) above it; measured number outside the range, below it.
By their numbers in this assay, from the lowest: compounds 3, 1 and 2 (each within the scatter of the next, the first and the last beyond it).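

In this assay, among these compounds, this place on the pendant phenyl turns out not to be indifferent to every change, since a 2.6-fold lower number from compound 2 to compound 3 (0.42 log units; beyond the scatter) is the first step here to pass the scatter. The step from hydrogen, a 2.0-fold lower number from compound 1 to compound 3 (0.30 log units; within the scatter), stays within it, so the data separate only methoxy from methyl, and compound 1 lies within the scatter of both. Nothing available gives a reason for this difference. Going by these compounds, what chlorine, an amine or a longer chain would do at this place stays open.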